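Swapping Methoxy for Dimethylamino on the Phenyl Arm

This account rests on a few compounds, and the source may have more. Where it says the series, first, only, none or still open, it means among the compounds named here.

Measured so far in a functional assay on cells (Homo sapiens) for antiproliferative activity, read by sulforhodamine B assay, with a stated time of 5 days; on this read-out lower numbers stand for stronger inhibition and higher numbers for weaker inhibition:
compound 1, `C#CCOc1ccc(C(C)(C)C)cc1C1(c2ccccc2)C(=O)Nc2ccccc21`: 17500 nM
compound 2, `CC(C)(C)c1ccc(OCC(=O)O)c(C2(c3ccccc3)C(=O)Nc3ccccc32)c1`: > 20000 nM, a limit of the assay
compound 3, `COc1ccc(C2(c3cc(C(C)(C)C)ccc3O)C(=O)Nc3ccccc32)cc1`: 2650 nM

Compound 2 sits at the limit of > 20000 nM in this assay, at which 1 of the 3 values shown sits, so its value is a limit and not a number. Among the two numbers, compound 3 gives the lowest, with compound 1 the nearest and higher. For the measured compounds named here, the one measured step, an at least 1.1-fold higher number from compound 1 to compound 2 (0.05 log units; that floor lies within the scatter), alters a chain on an oxygen and does not touch the place changed here. Compound 4, `CN(C)c1ccc(C2(c3cc(C(C)(C)C)ccc3O)C(=O)Nc3ccccc32)cc1`, differs from compound 3 by dimethylamino in place of methoxy on an aromatic carbon. Going by the values given here, no measured step bears on this change, so the estimated step of a 1.1-fold lower number from compound 3 to compound 4 (0.03 log units; within the scatter) is expected to stay within the scatter. Compound 4 is therefore expected to give 2500 nM, in the range 800 nM to 8000 nM.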

Compound 4, half-maximal inhibitory concentration: 2300 nM
Compound 4: middle estimate off by 1.1-fold (0.04 log units), on the high side; the measured number falls inside the stated range.
By their numbers in this assay, from the lowest: compounds 4 and 3 (each within the scatter of the next); then compound 1. At a limit, above all of these: compound 2.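

For the compounds shown here, until now, no measured step touched the phenyl arm. In this assay, dimethylamino in place of methoxy gives a 1.2-fold lower number from compound 3 to compound 4 (0.06 log units; within the scatter), so at this place, para to a large group, the two groups cannot be told apart on this read-out. Nothing measured here tells why the two groups match.

From the compounds shown here alone, whether a primary amine, a fluorine atom or a longer chain such as ethoxy would hold the same level at this place remains open. So does whether any group here could move the number beyond the scatter.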